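The source may hold more compounds than are shown below. What is called first, only, known or untested is meant among the compounds shown, and "the series" means these compounds.

In a functional assay on MCF7 cells (Homo sapiens) for antiproliferative activity, read by MTT assay, with a stated time of 24 h, tested at 0.01 ug/mL (a lower number here means a stronger effect, a higher number a weaker effect of the compound at the concentration tested), compound 1 `O=Cc1cn(-c2ccccc2)nc1-c1ccc(Cl)cc1` gives 98% and compound 2 `COc1cc(/C=C/C(=O)C(=Cc2cn(-c3ccccc3)nc2-c2ccc([N+](=O)[O-])cc2)C(=O)/C=C/c2ccc(O)c(OC)c2)ccc1O` gives 95%. The two values lie within the scatter of each other, so on the numbers shown compound 2 stands at the same level as compound 1, both near the point where the compounds show little effect. Compound 3 `COc1cc(/C=C/C(=O)C(=Cc2cn(-c3ccccc3)nc2-c2ccc(Cl)cc2)C(=O)/C=C/c2ccc(O)c(OC)c2)ccc1O` differs from compound 2 in one place: chloro in place of nitro on an aromatic carbon. Within the data shown here, no step is measured for this change, and the two known values give no sign of one beyond the scatter. In this assay compound 3 is therefore expected at 97%, between 87% and 105%. The expected step of a number 2 percentage points higher from compound 2 to compound 3 (within the scatter) is none beyond the scatter.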

Compound 3, a percentage reported as activity, at one concentration (the size of the read-out at that concentration, not a potency): 75%
Beside the measured number, compound 3's estimate is 22 percentage points above it; the whole stated range lies above it.
By their numbers in this assay, from the lowest: compound 3; then compounds 2 and 1 (each within the scatter of the next).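

In this assay the group on this aromatic carbon, para to a large group, is not neutral to the read-out: the change from 4-nitrophenyl to 4-chlorophenyl gives a number 20 percentage points lower from compound 2 to compound 3 (beyond the scatter), a modest move towards a stronger effect at the concentration tested. Nothing shown accounts for this step. The compounds shown leave open whether a group such as an amine or a carboxylic acid at this position would lower the number further or raise it. They also leave open whether the step persists at other concentrations.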